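Loss of the 2,5-dioxopyrrolidin-3-yl group: compound 4

A few compounds are considered here, and "the series" means these few. Any claim that something is new, unique, unknown or untested is made for them only; others in the source may bear on it.

Compound 2 `COc1ccc2[nH]c(-c3ccc[nH]3)c(C3CC(=O)NC3=O)c2c1` is the anchor of this step. In a functional assay on B16-F10 cells (Mus musculus) for cytotoxicity, read by MTT assay, with a stated time of 72 h (on this read-out lower numbers stand for stronger inhibition and higher numbers for weaker inhibition), compound 2 gives 600 nM, second highest of the three numbers and nearest to compound 1. Compound 1 `Cc1ccc2[nH]c(-c3ccc[nH]3)c(C3CC(=O)NC3=O)c2c1` gives 500 nM in this assay, and the step of a 1.2-fold higher number from compound 1 to compound 2 (0.08 log units; within the scatter) stays within the scatter. Compound 3 `COc1ccc2[nH]c3c(c4c(n5cccc35)C(=O)N(C)C4=O)c2c1` gives 27000 nM in this assay, far beyond compounds 1 and 2. Compound 4 `COc1ccc2[nH]c(-c3ccc[nH]3)cc2c1` differs from compound 2 by hydrogen in place of 2,5-dioxopyrrolidin-3-yl on an aromatic carbon. Among the measured compounds shown here, no measured step removes this group, so no step bears directly on the change; the only guide is that the one heavily altered compound, compound 3, lies far higher. Compound 4 is therefore expected to give a clearly higher number, the expected step being a 17-fold higher number from compound 2 to compound 4 (1.22 log units; beyond the scatter). The estimate for compound 4 is 10000 nM, with a range from 2000 nM to 60000 nM.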

Compound 4, half-maximal inhibitory concentration: 61000 nM
Compound 4: middle estimate off by 6.1-fold (0.79 log units), on the low side; the whole stated range lies below it.
By their numbers in this assay, from the lowest: compounds 1 and 2 (each within the scatter of the next); then compound 3; then compound 4.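

In this assay, among the compounds shown here, replacing 2,5-dioxopyrrolidin-3-yl with hydrogen on this aromatic carbon gives a 100-fold higher number from compound 2 to compound 4 (2.01 log units; beyond the scatter) and is the first measured change at this position. The number here depends strongly on this substituent, whereas the swap of methyl for methoxy elsewhere on the shared core gives a 1.2-fold higher number from compound 1 to compound 2 (0.08 log units; within the scatter) and stays within the scatter. Nothing available explains the size of the new step.

Going by these compounds, it remains open whether the intact ring is needed. A carboxylic acid, an acetamide chain or an amine on this carbon could show whether a simpler group keeps the number near that of compound 2.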